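The compounds below may be only part of what the source reports. "The series", "measured", "known", "first", "only" and "open" are said of these compounds alone.

Of the compounds shown here, three have been measured in an assay on isolated protein for inhibition of thyroid hormone receptor alpha (Homo sapiens), read by fluorescence polarization; on this read-out lower numbers stand for stronger inhibition and higher numbers for weaker inhibition. Compound 1 `CS(=O)(=O)c1ccc(C(=O)NCC(=O)N(Cc2ccccc2)Cc2ccccc2)cc1[N+](=O)[O-]` gives 1700 nM in this assay. Compound 2 `CS(=O)(=O)c1ccc(C(=O)NCCCC(=O)N2Cc3ccccc3C2)cc1[N+](=O)[O-]` returns only a limit in this assay, namely > 60000 nM, and no number. Compound 3 `CS(=O)(=O)c1ccc(C(=O)N2CCC(C(=O)N(Cc3ccccc3)Cc3ccccc3)CC2)cc1[N+](=O)[O-]` likewise returns only a limit in this assay, namely > 60000 nM. Compound 2 therefore stands at the limit of > 60000 nM in this assay, at which 2 of the 3 values shown sit: its result is a limit rather than a number, and one further value among those shown is also a limit, so no step between two measured compounds can be read off from these data.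

The unmeasured compound 4 `CN(Cc1cccc(F)c1)C(=O)CCCNC(=O)c1ccc(S(C)(=O)=O)c([N+](=O)[O-])c1` differs from compound 2 in one place: a group of 10 heavy atoms (8 carbon, 1 nitrogen, 1 fluorine; one six-membered aromatic ring of carbon only) in place of a group of 9 heavy atoms (8 carbon, 1 nitrogen; one five-membered non-aromatic ring with 1 hetero atom, one six-membered aromatic ring of carbon only), on a carbonyl carbon. For the measured compounds named here, with no measured step to lean on, the expectation rests only on the change itself and on the fact that compound 2 gave no number. The expected step, an at least 1.5-fold lower number from compound 2 to compound 4 (0.17 log units; that floor lies within the scatter), is modest, pointing if anywhere toward stronger inhibition in this assay but not with confidence beyond the usual scatter. The estimate for compound 4 in this assay is 40000 nM, within a range from 8000 nM to 150000 nM, and it remains quite possible that this assay again reports only a limit for compound 4.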

Compound 4, half-maximal inhibitory concentration: > 60000 nM
Compound 4: a limit, no number; the forecaster's own chance of this, stated with the estimate: 55%; at least 1.5-fold (0.17 log units) between middle value and limit.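

Compound 4 returns only a limit of > 60000 nM in this assay and no number. For the compounds shown here, compound 2 likewise gave only a limit, so no step from compound 2 to compound 4 can be read. The compounds shown leave open how strongly either compound inhibits, and whether the (3-fluorobenzyl)(methyl)amino group on the carbonyl carbon differs at all from the group it replaces.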